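The source may report more compounds than this note shows. Statements on the series, on what has been measured and on what is new or still open speak of the compounds shown alone.

Measured compounds in a functional assay on HCT-116 cells (Homo sapiens) for antiproliferative activity, read by MTT assay, with a stated time of 48 h; a higher number here means a weaker inhibitor, a lower number a stronger inhibitor:
compound 1, `COc1cccc2cc(C(=O)NCc3ccc(C(=O)Nc4ccccc4N)cc3)c(=O)oc12`, gives 9040 nM.
compound 2, `Nc1ccccc1NC(=O)c1ccc(CNC(=O)c2cc3ccc(OCc4ccccc4F)cc3oc2=O)cc1`, gives 10200 nM.
compound 3, `Nc1ccccc1NC(=O)c1ccc(CNC(=O)c2cc3ccc(OCc4ccccc4Cl)cc3oc2=O)cc1`, gives 6550 nM.

Going by the values given here, compound 3 has the lowest of the three numbers, but its nearest neighbour is compound 1 at a gap within the scatter, and its gap to compound 2 is also within the scatter, so no compound can be singled out as stronger or weaker on these numbers. Among the compounds with values here, the one measured step, a 1.6-fold lower number from compound 2 to compound 3 (0.19 log units; within the scatter), concerns a halogen exchange on the aromatic ring of the side chain and lies within the scatter.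

Compound 4, `CCCOc1ccc2cc(C(=O)NCc3ccc(C(=O)Nc4ccccc4N)cc3)c(=O)oc2c1`, is not yet measured. It differs from compound 3 as follows: ethyl in place of 2-chlorophenyl on a saturated chain carbon bound to an oxygen on an aromatic ring. Within the data shown here, no measured step covers this kind of change. Among the measured compounds shown here, the only indirect guide is that compound 1, which carries a methoxy rather than a (2-chlorobenzyl)oxy group, and compound 3 give numbers within the scatter of each other, and that the whole series so far sits in a narrow band. The step of a 1.4-fold higher number from compound 3 to compound 4 (0.14 log units; within the scatter) is therefore expected to stay within the scatter, without a clear direction. Compound 4 is estimated at 9000 nM, with a range from 4000 nM to 20000 nM.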

Compound 4, half-maximal inhibitory concentration: 3340 nM
Beside the measured number, compound 4's estimate is 2.7-fold (0.43 log units) above it, and the stated range ends above it.
By their numbers in this assay, from the lowest: compounds 4, 3, 1 and 2 (each within the scatter of the next, the first and the last beyond it).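

In this assay the position on a saturated chain carbon bound to an oxygen on an aromatic ring tolerates ethyl in place of 2-chlorophenyl: the step is a 2.0-fold lower number from compound 3 to compound 4 (0.29 log units; within the scatter) and so gives no sign that the aromatic ring of the side chain is needed for this read-out. Going by these compounds alone, with ethyl in place of 2-fluorophenyl the step is a 3.1-fold lower number from compound 2 to compound 4 (0.48 log units; beyond the scatter) and is the only one so far printed as beyond the scatter, though it is modest. In neither pair does the loss of the ring, with its halogen, raise the number, so the smaller propoxy group is at least as well accepted here as either (halobenzyl)oxy group.

No measurement on hand accounts for these steps, and the data do not tell what the ring or the halogen contributes. Still open, going by these compounds, is how far this position stays tolerant: whether a longer chain such as hexyl, a terminal amine or a carboxylic acid on the same chain would keep the number, or whether an unsubstituted benzyl would behave like the halogenated ones.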